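Second trifluoromethyl on the aryl urea, two cases

The source may report more compounds than this note shows. Statements on the series, on what has been measured and on what is new or still open speak of the compounds shown alone.

Compound 2 `COc1cc(NC(C)CCCNC(=O)Nc2cccc(C(F)(F)F)c2)c2ncccc2c1`, compound 1 `COc1cc(NC(C)CCCNC(=O)Nc2cc(C(F)(F)F)cc(C(F)(F)F)c2)c2ncccc2c1`, compound 3 `COc1cc(NC(C)CCCNC(=O)NNC(=O)Nc2cccc(C(F)(F)F)c2)c2ncccc2c1` and compound 4 `COc1cc(NC(C)CCCNC(=O)NNC(=O)Nc2cc(C(F)(F)F)cc(C(F)(F)F)c2)c2ncccc2c1` belong to one series; the difference between the cores of compound 2 and compound 3 is not broken down here. In a functional assay on MIA PaCa-2 cells (Homo sapiens) for inhibition, read by MTT assay, with a stated time of 72 h (on this read-out higher numbers stand for weaker inhibition and lower numbers for stronger inhibition), compound 2 gives 17000 nM and compound 1 gives 4700 nM; the change trifluoromethyl in place of hydrogen on an aromatic carbon made a 3.6-fold lower number from compound 2 to compound 1 (0.56 log units; beyond the scatter). Compound 3 gives 5600 nM in this assay, close to compound 1. Compound 4 carries the same change against compound 3, (trifluoromethyl in place of hydrogen on an aromatic carbon), and the surroundings of the place read alike in both pairs. With only one earlier case to go on, a step of similar size is expected, so the estimated step is a 3.1-fold lower number from compound 3 to compound 4 (0.49 log units; beyond the scatter), resting on a 3.6-fold lower number from compound 2 to compound 1 (0.56 log units; beyond the scatter). Compound 4 is therefore estimated at 1800 nM in this assay, expected between 700 nM and 4500 nM.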

Compound 4, half-maximal inhibitory concentration: 20000 nM
Estimate against measurement, compound 4: 11-fold (1.05 log units) below; measured number outside the range, above it.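

In this assay the change does not carry over between these two cores, as it gives a 3.6-fold higher number from compound 3 to compound 4 (0.55 log units; beyond the scatter), against the direction seen on the core of compound 2: the same change on two cores in this assay, a 3.6-fold lower number (0.56 log units; beyond the scatter) from compound 2 to compound 1 and a 3.6-fold higher number (0.55 log units; beyond the scatter) from compound 3 to compound 4, 13-fold (1.11 log units) apart, beyond the scatter of two such steps A step taken from the core of compound 2 therefore gave no usable guide to the core of compound 3. For the compounds shown here, with only two pairs, this shows that the step differs between these cores, but not which part of the core difference goes with the reversal, nor why it occurs.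

As far as these compounds go, it remains open whether a chlorine or a nitrile in place of the second trifluoromethyl would split the two cores in the same way. From the compounds shown here alone, it also remains open whether a longer chain on either core would keep the step seen on that core.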